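The compounds below may be only part of what the source reports. "The series", "measured", "known", "first", "only" and "open" are said of these compounds alone.

Measured compounds in a functional assay on MCF7 cells (Homo sapiens) for antiproliferative activity, read by MTT assay, with stated times of 24 h and 72 h; on this read-out higher numbers stand for weaker inhibition and lower numbers for stronger inhibition:
compound 1, `COc1ccc([C@@H]2[C@H](Oc3ccccc3)C(=O)N2c2cc(OC)c(OC)c(OC)c2)cc1OC`, 26000 nM
compound 2, `COc1ccc([C@@H]2[C@H](Oc3ccccc3)C(=O)N2c2cc(OC)c(OC)c(OC)c2)cc1[N+](=O)[O-]`, 69000 nM

Compound 2 stands highest of the two numbers shown; its nearest neighbour is compound 1, and a 2.7-fold higher number from compound 1 to compound 2 (0.42 log units; beyond the scatter) is the only measured step in the series. Both compounds share a core, and the step between them changes only the substitution on the aryl ring attached to the saturated ring carbon.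

Compound 3, `COc1cc(N2C(=O)[C@@H](Oc3ccccc3)[C@H]2c2ccc(S(C)(=O)=O)cc2)cc(OC)c1OC`, is not yet measured. It differs from compound 2 by 4-(methylsulfonyl)phenyl in place of 4-methoxy-3-nitrophenyl on a saturated ring carbon. The measured step from compound 1 to compound 2 bears on this, as it also alters the substituents of the same aryl ring, and it was modest in size. For the measured compounds named here, a step of similar, modest size is expected here, the direction being open, since the entering group has no precedent. The expected step is a 1.7-fold lower number from compound 2 to compound 3 (0.24 log units; within the scatter), and compound 3 is estimated at 40000 nM, in the range 10000 nM to 150000 nM.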

Compound 3, half-maximal inhibitory concentration: 62000 nM
The estimate for compound 3 lay 1.6-fold (0.19 log units) below the measured number; the measured number falls inside the stated range.
By their numbers in this assay, from the lowest: compound 1; then compounds 3 and 2 (each within the scatter of the next).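

In this assay, a 1.1-fold lower number from compound 2 to compound 3 (0.05 log units; within the scatter) shows that 4-(methylsulfonyl)phenyl and 4-methoxy-3-nitrophenyl cannot be told apart at this saturated ring carbon, although the entering group carries neither a nitro nor a methoxy group. With a 2.4-fold higher number from compound 1 to compound 3 (0.38 log units; beyond the scatter), a second replacement of 3,4-dimethoxyphenyl also gives a higher number, so both steps away from compound 1 lie beyond the scatter. No measurement at hand accounts for these numbers.

As far as these compounds go, it remains open whether an aryl ring bearing a hydroxyl or an amino group at this carbon would match compound 1 at 26000 nM. From the compounds shown here alone, the effect of replacing the phenoxy group with an amine on the neighbouring ring atom also remains open.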